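A Smaller Aryl Cap on a Weakly Cytotoxic Anilide

This account rests on a few compounds, and the source may have more. Where it says the series, first, only, none or still open, it means among the compounds named here.

Compound 2 `COc1cc(/C=C/C(=O)Nc2cc3c(Nc4ccc(F)c(Cl)c4)ncnc3cc2O[C@H]2CCOC2)cc(OC)c1` is the reference point. In a functional assay on MCF7 cells (Homo sapiens) for cytotoxicity, read by MTT assay, with a stated time of 72 h (a higher number here means a weaker inhibitor, a lower number a stronger inhibitor), compound 2 gives 30300 nM, the lowest of the two numbers reported, but its nearest neighbour compound 1 `COc1cc(/C=C/C(=O)Nc2cc3c(Nc4ccc(F)c(Cl)c4)ncnc3cc2OC)cc(OC)c1` gives 38500 nM, and the step of a 1.3-fold lower number from compound 1 to compound 2 (0.10 log units; within the scatter) stays within the scatter, so the two cannot be ranked. A close relative, compound 3 `COc1cc2ncnc(Nc3ccc(F)c(Cl)c3)c2cc1NC(=O)/C=C/c1cc(OC)c(OC)c(OC)c1`, gives "not active" (no number reported). Compound 4 `COc1ccc(/C=C/C(=O)Nc2cc3c(Nc4ccc(F)c(Cl)c4)ncnc3cc2O[C@H]2CCOC2)cc1` has not yet been measured. It differs from compound 2 in one place: 4-methoxyphenyl in place of 3,5-dimethoxyphenyl on a double-bonded chain carbon bound to a double-bonded chain carbon. None of the measured steps touches this part of the molecule; the one step shown alters the group on an oxygen on the core instead, and the values of compound 1 and compound 3 only show that one relative returned a number while the other did not. Without a comparable step, no direction beyond the scatter can be expected, and the range must stay wide. Compound 4 is estimated at 40000 nM, between 10000 nM and 150000 nM, an expected step of a 1.3-fold higher number from compound 2 to compound 4 (0.12 log units; within the scatter).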

Compound 4, half-maximal inhibitory concentration: 5070 nM
Estimate against measurement, compound 4: 7.9-fold (0.90 log units) above; the measured number lies below the stated range.
By their numbers in this assay, from the lowest: compound 4; then compounds 2 and 1 (each within the scatter of the next).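

Within the data shown here, the group on the double-bonded chain carbon can clearly shift the result in this assay: swapping 3,5-dimethoxyphenyl for 4-methoxyphenyl gives a 6.0-fold lower number from compound 2 to compound 4 (0.78 log units; beyond the scatter), whereas the only earlier step, at the oxygen on the core, stayed within the scatter. Compound 4 therefore has the lowest number of the series, and this end of the molecule is the first place shown where a single change makes a readable difference. Nothing measured here separates the possible contributions of the lost oxygen, the lower heavy-atom count and the altered arrangement of methoxy groups, so the step remains unexplained.

Going by these compounds, it remains open whether the same swap would have a similar effect with methyl on the core oxygen, as in compound 1. The compounds shown also leave open how a plain phenyl ring, or an aryl group carrying an amine or a carboxylic acid, would behave here.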